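The source may hold more compounds than are shown below. What is called first, only, known or untested is meant among the compounds shown, and "the series" means these compounds.

Compound 2 `CC1=C(C(=O)OC(C(F)(F)F)C(F)(F)F)C(c2cccs2)NC(=O)N1` in an assay on HEK293 cells for displacement of a labelled ligand from adenosine receptor A2b (Homo sapiens), read by radioligand binding, with a stated time of 30 min, tested at 1 uM (on this read-out lower numbers stand for less inhibition and higher numbers for more inhibition at the one concentration tested (going by the name of the read-out)), gives 1%. Among the compounds with values here, compound 1 `CC1=C(C(=O)OC(C(F)(F)F)C(F)(F)F)C(c2ccsc2)NC(=O)N1`, carrying thiophen-3-yl on the saturated ring carbon, gives 1%; the step of no change at the digits printed from compound 1 to compound 2 (within the scatter) is the only measured step in the set and shows no change within the scatter. Compound 2 therefore stands level with compound 1 at the digits shown, and both sit at the low end of the read-out.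

Compound 3 `CC1=C(C(=O)OC(C(F)(F)F)C(F)(F)F)C(c2ccco2)NC(=O)N1` has not been measured. It differs from compound 2 by furan-2-yl in place of thiophen-2-yl on a saturated ring carbon. Within the data shown here, only the step from compound 1 to compound 2 bears on this, since it too exchanged one five-membered aromatic ring with 1 hetero atom on the saturated ring carbon, and it was flat. Accordingly no step beyond the scatter is expected in this assay, and the step of a number 1 percentage points higher from compound 2 to compound 3 (within the scatter) is estimated as flat. For compound 3 the expected value is 2%, with a range from -8% to 12%.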

Compound 3, a percentage reported as inhibition, at one concentration (the size of the read-out at that concentration, not a potency): 1%
Estimate against measurement, compound 3: 1 percentage points above; low and high end bracket the measured number.
By their numbers in this assay, from the lowest: compounds 1, 2 and 3 (each within the scatter of the next).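

Exchanging thiophen-2-yl for furan-2-yl on the saturated ring carbon gives no change at the digits printed from compound 2 to compound 3 (within the scatter) in this assay, so the hetero atom of the five-membered aromatic ring has now been varied at this position, whereas the earlier step moved only the point of attachment of the thiophene. Furan-2-yl in place of thiophen-3-yl gives no change at the digits printed from compound 1 to compound 3 (within the scatter), so changing the hetero atom and the attachment together also leaves the read-out flat. No measurement at hand offers any explanation for this flat result.

All three compounds sit at the low end of the read-out, so it does not separate these rings. Going by these compounds, whether a phenyl or pyridyl ring at this position, or an ethyl ester on the shared core, would lift the number off that floor remains open.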